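Replacing a benzyl link with a tert-butylphenyl group

The compounds below may be only part of what the source reports. "The series", "measured", "known", "first", "only" and "open" are said of these compounds alone.

Measured compounds:
- compound 1, `Cc1ccccc1Nc1nc(Nc2ccc(N3CCN(C(=O)OC(C)(C)C)CC3)cc2)ncc1Cl`: 2250 nM
- compound 2, `Cc1ccc(CNc2nc(Nc3ccc(N4CCN(C)CC4)cn3)ncc2Cl)cc1`: 38100 nM

In a functional assay on MCF7 cells (Homo sapiens) for inhibition, read by CCK-8 assay, with a stated time of 48 h (on this read-out lower numbers stand for stronger inhibition of growth and higher numbers for weaker inhibition of growth), compound 1 gives 2250 nM. Compound 2 gives 38100 nM in this assay, the higher of the two numbers, so it inhibits growth more weakly than compound 1, and the gap between the two lies beyond the usual scatter. Compound 3, `CN1CCN(c2ccc(Nc3ncc(Cl)c(Nc4ccc(C(C)(C)C)cc4)n3)nc2)CC1`, has not yet been measured. It differs from compound 2 in one place: 4-(tert-butyl)phenyl in place of 4-methylbenzyl on a nitrogen on an aromatic ring. In compound 3 the ring-nitrogen carries an aromatic ring directly, as in compound 1, where the lower number was found; this does not settle the outcome, since compound 1 differs from compound 3 in other places as well. Still, the expected step from compound 2 to compound 3 in this assay is a 6.4-fold lower number from compound 2 to compound 3 (0.80 log units; beyond the scatter), toward stronger inhibition. Compound 3 is estimated at 6000 nM, within 1200 nM to 30000 nM.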

Compound 3, concentration for 50% growth inhibition: 12600 nM
The estimate for compound 3 lay 2.1-fold (0.32 log units) below the measured number, within the range that was stated.
By their numbers in this assay, from the lowest: compound 1; then compound 3; then compound 2.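

In this assay the swap of 4-methylbenzyl for 4-(tert-butyl)phenyl on a nitrogen on an aromatic ring gives a 3.0-fold lower number from compound 2 to compound 3 (0.48 log units; beyond the scatter) as a modest step toward stronger inhibition of growth. For the compounds shown here, this is the first reading of a change in one place only, and it shows that the group on this nitrogen can move the number beyond the usual scatter. Nothing measured here accounts for the step.

The swap alters two things at once, since the benzyl link gives way to a ring set directly on the nitrogen while the methyl gives way to tert-butyl, and the compounds shown cannot separate these two parts. A 4-methylphenyl or an unsubstituted phenyl on this nitrogen would be needed to tell them apart.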